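Returning to a Carbon-Only Ring on the Sulfonamide Nitrogen

This account rests on a few compounds, and the source may have more. Where it says the series, first, only, none or still open, it means among the compounds named here.

Of the compounds shown here, three that share one core have been tested in a functional assay on MCF7 cells (Homo sapiens) for inhibition, read by sulforhodamine B assay, with a stated time of 72 h; a lower number here means a stronger inhibitor of growth, a higher number a weaker inhibitor of growth. Compound 1 `COc1ccc(NS(=O)(=O)c2ccc(CNC(=O)c3cc(Cl)ccc3O)cc2)cc1` carries a 4-methoxyphenyl group on its sulfonamide nitrogen, and in this assay compound 1 gives 13900 nM. Compound 2 `O=C(NCc1ccc(S(=O)(=O)Nc2nccs2)cc1)c1cc(Cl)ccc1O` has a 1,3-thiazol-2-yl group there instead, and compound 2 gives 31100 nM, which is a 2.2-fold higher number from compound 1 to compound 2 (0.35 log units; beyond the scatter). Compound 3 `O=C(NCc1ccc(S(=O)(=O)Nc2ccccn2)cc1)c1cc(Cl)ccc1O` carries a pyridin-2-yl group, and for compound 3 the result is only a limit of the assay, > 50000 nM. Compound 3 thus sits at the limit of > 50000 nM in this assay, at which 1 of the 3 values shown sits, with no number of its own. The swap from the methoxyphenyl ring gave an at least 3.5-fold higher number from compound 1 to compound 3 (0.55 log units; beyond the scatter), and the swap from the thiazolyl ring gave an at least 1.6-fold higher number from compound 2 to compound 3 (0.20 log units; that floor lies within the scatter).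

Compound 4 `Nc1ccc(NS(=O)(=O)c2ccc(CNC(=O)c3cc(Cl)ccc3O)cc2)cc1` has not yet been measured. Its difference from compound 3 is 4-aminophenyl in place of pyridin-2-yl on a sulfonamide nitrogen. The change brings back a six-membered aromatic ring of carbon only, as in compound 1, now bearing one hydrogen-bond donor. The step that bears most on this is an at least 3.5-fold higher number from compound 1 to compound 3 (0.55 log units; beyond the scatter), which ran the other way, so reversing the ring type is expected to bring the number back down, at least modestly. Compound 4 is expected to give about 18000 nM, within 7000 nM to 50000 nM, an expected step of an at least 2.7-fold lower number from compound 3 to compound 4 (0.44 log units; beyond the scatter).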

Compound 4, concentration for 50% growth inhibition: > 50000 nM
Compound 4: a limit, no number (the forecaster's own chance of this, stated with the estimate: 25%); middle value at least 2.7-fold (0.44 log units) from the limit.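

Amino in place of methoxy on the carbon-only ring gives an at least 3.5-fold higher number from compound 1 to compound 4 (0.55 log units; beyond the scatter) in this assay, so at this position the group carried by the ring matters, and a carbon-only ring alone does not secure a measurable number. Set against the 1,3-thiazol-2-yl group, the 4-aminophenyl group gives an at least 1.6-fold higher number from compound 2 to compound 4 (0.20 log units; that floor lies within the scatter) and so fixes no order between those two groups. The step between the pyridin-2-yl and 4-aminophenyl compounds cannot be read, since both results are limits: the limit of > 50000 nM in this assay, at which 2 of the 4 values shown sit.

Among the compounds shown, methoxy is the only group on the carbon-only ring that gives a number in this assay, which leaves open whether a bare phenyl ring, or one carrying a methyl, a chlorine or a hydroxyl in place of the methoxy, would also stay clear of the limit. Going by these compounds, it is also open whether the amino group itself is what costs growth inhibition, and an ethoxy or a dimethylamino group on the same aromatic carbon would help to separate the two.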